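Taking one 2H-tetrazol-5-yl group off compound 3

This account rests on a few compounds, and the source may have more. Where it says the series, first, only, none or still open, it means among the compounds named here.

For the measured compounds named here, in a functional assay on the whole organism with Rattus norvegicus as the target, at a dose of 25 mg/kg by the intravenous route (on this read-out lower numbers stand for an effect already at smaller amounts and higher numbers for an effect only at larger amounts of compound), compound 3 (`O=C(Nc1cccc(-c2nn[nH]n2)c1)c1cccc(-c2nn[nH]n2)c1`) gives 1.6 mg/kg, the lowest of the three numbers so far. Compound 2 (`O=C(Nc1ccccc1)c1ccc(-c2nn[nH]n2)cc1`) gives 8.4 mg/kg and compound 1 (`CCCCc1ccc(C(=O)Nc2cc(C(=O)O)cc(C(=O)O)c2)cc1`) gives 12.3 mg/kg, both higher than that and beyond the scatter.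

The next structure is compound 4 (`O=C(Nc1ccccc1)c1cccc(-c2nn[nH]n2)c1`), which differs from compound 3 as follows: hydrogen in place of 2H-tetrazol-5-yl on an aromatic carbon. In words, hydrogen stands in place of 2H-tetrazol-5-yl on an aromatic carbon. Going by the values given here, no two measured compounds differ in one place only, so the series offers no direct precedent for the size of this step. The nearest guide is compound 2, which also carries a single 2H-tetrazol-5-yl group and gives 8.4 mg/kg. A number in that region is therefore the working expectation, which means a move to a higher number in this assay, beyond the scatter.

The expected step is a 4.4-fold higher number from compound 3 to compound 4 (0.64 log units; beyond the scatter).

Compound 4 is estimated at 7 mg/kg, with an expected range of 3 mg/kg to 18 mg/kg.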

Compound 4, dose for 50% inhibition: 4.5 mg/kg
For compound 4 the middle estimate is 1.6-fold (0.19 log units) above the measured one; the measured number falls inside the stated range.
By their numbers in this assay, from the lowest: compound 3; then compounds 4, 2 and 1 (each within the scatter of the next, the first and the last beyond it).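

For the compounds shown here, on this position, meta to a large group on a six-membered aromatic ring of carbon only, hydrogen in place of 2H-tetrazol-5-yl gives a 2.8-fold higher number from compound 3 to compound 4 (0.45 log units; beyond the scatter) in this assay and so provides the first one-place step. The 2H-tetrazol-5-yl group at this position therefore has a measurable bearing on the read-out, yet its loss does not remove the effect, since compound 4 still gives 4.5 mg/kg at this stage of the series. No supporting measurement bears on the reason for this step.

Going by these compounds, it remains open whether another group at this position, such as a nitrile or an amine, would match the 2H-tetrazol-5-yl group or hydrogen. On these data alone, the effect of removing the remaining 2H-tetrazol-5-yl group from compound 4 also remains open.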